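This account rests on a few compounds, and the source may have more. Where it says the series, first, only, none or still open, it means among the compounds named here.

Series notes. Compound 1 `O=C(c1sc(-c2cccc(F)c2)nc1O)N1CCOC1` gives 5500 nM in an assay on HEK293 cells for inhibition of transient receptor potential cation channel subfamily M member 8 (Homo sapiens), read by FLIPR, with stated times of 5 min and 3 min; a higher number here means a weaker inhibitor, a lower number a stronger inhibitor. Compound 2 `O=C(c1sc(-c2cccc(F)c2)nc1O)N1CCCOC1` reaches only the assay limit, > 100000 nM in this assay. Compound 3 `CCOC(=O)c1ccc(-c2cccc(F)c2)cc1O` likewise sits at the limit, > 100000 nM in this assay. Within the data shown here, the single measured step, an at least 18-fold higher number from compound 1 to compound 2 (1.25 log units; beyond the scatter), is the only guide here, and the limit of > 100000 nM in this assay, at which 2 of the 3 values shown sit, marks where compound 2 stands. Compound 4 `CCON(C)C(=O)c1sc(-c2cccc(F)c2)nc1O` differs from compound 2 by a group of 5 heavy atoms (3 carbon, 1 nitrogen, 1 oxygen; no ring) in place of a group of 6 heavy atoms (4 carbon, 1 nitrogen, 1 oxygen; one six-membered non-aromatic ring with 2 hetero atoms), on a carbonyl carbon, so the six-membered ring of that step gives way to an open chain of the same atom count as the ring of compound 1. Among the measured compounds shown here, no measured step covers such a chain on the carbonyl carbon, so only a partial return toward compound 1 is expected, with wide uncertainty. Compound 4 is therefore expected near 30000 nM, within 5000 nM to 150000 nM. The expected step is an at least 3.3-fold lower number from compound 2 to compound 4 (0.52 log units; beyond the scatter).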

Compound 4, half-maximal inhibitory concentration: 1680 nM
Estimate against measurement, compound 4: 18-fold (1.25 log units) above, outside the stated range (below it).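

The carbonyl carbon does not need a ring: the open ethoxy(methyl)amino group gives a 3.3-fold lower number from compound 1 to compound 4 (0.52 log units; beyond the scatter), so in this assay the chain improves on the five-membered ring. The shared core alone therefore does not account for the loss with the six-membered ring, as an at least 59-fold lower number from compound 2 to compound 4 (1.77 log units; beyond the scatter) shows. That step has only a lower bound, set by an assay limit: the limit of > 100000 nM in this assay, at which 2 of the 4 values shown sit.

From the compounds shown here alone, what a dimethylamino group or a longer chain such as propoxy(methyl)amino would give on the carbonyl carbon stays open. So does whether the oxygen of the ethoxy(methyl)amino group is needed at all.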